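A few compounds are considered here, and "the series" means these few. Any claim that something is new, unique, unknown or untested is made for them only; others in the source may bear on it.

In a physicochemical assay for solubility, using the shake flask method, in simulated intestinal fluid, measured as kinetic solubility, with a stated time of 2 h, at 25 degrees C, at pH 6.5 (a higher number here means a more soluble compound, a lower number a less soluble compound), compound 1 `Cc1nc(C(=O)O)c(N)c2c1C(=O)N(Cc1ccccc1)C2=O`, which carries a carboxy group, gives 177000 nM. Compound 2 `Cc1nc(-c2nc(C(F)(F)F)no2)c(N)c2c1C(=O)N(Cc1ccccc1)C2=O` is recorded as < 5000 nM, which is a limit of the assay and not a number. Compound 3 `Cc1noc(-c2nc(C)c3c(c2N)C(=O)N(CC2CCOCC2)C3=O)n1` gives 5700 nM, the lower of the two true numbers and far under the figure for compound 1.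

Compound 4 `Cc1noc(-c2nc(C)c3c(c2N)C(=O)N(Cc2cccc(F)c2)C3=O)n1` keeps the core of compound 3 and differs in one place: 3-fluorophenyl in place of oxan-4-yl on a saturated chain carbon bound to an amide-type nitrogen in a ring. Read one bond further out, (oxan-4-yl)methyl gives way to 3-fluorobenzyl.

Among the measured compounds shown here, the only measured step, an at least 35-fold lower number from compound 1 to compound 2 (1.54 log units; beyond the scatter), was large, but it replaces the carboxy group and leaves the benzyl group untouched, so it offers only indirect guidance. Compound 2, which also has a benzyl group, stands at the limit of < 5000 nM in this assay, at which 1 of the 3 values shown sits, so a modest step down is expected in this assay. The expected change is a 2.3-fold lower number from compound 3 to compound 4 (0.36 log units; beyond the scatter). For compound 4 the estimated value is 2500 nM, with an expected range from 800 nM to 6500 nM.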

Compound 4, solubility: < 5000 nM
Compound 4: a limit, no number; the forecaster's own chance of this, stated with the estimate: 70%; the middle value is on the limit's open side.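

In this assay compound 4 is recorded as < 5000 nM, which is a limit of the assay and not a number. This is the first change shown on a saturated chain carbon bound to an amide-type nitrogen in a ring, and 3-fluorophenyl in place of oxan-4-yl gives an at least 1.1-fold lower number from compound 3 to compound 4 (0.05 log units; that floor lies within the scatter), so a real drop is possible but not shown, and its size stays unknown. With this result, a second compound in the set has no number that can be ranked: the limit of < 5000 nM in this assay, at which 2 of the 4 values shown sit.

The compounds shown leave open how far past its limit compound 4 lies, and so how much the change at this place really costs. Also open, on these data alone, is what a plain benzyl group or an amine on this chain would give on the core of compound 3, where a true number can still be read.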